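The source may hold more compounds than are shown below. What is called first, only, known or untested is meant among the compounds shown, and "the series" means these compounds.

Measured so far:
compound 1, `COc1ccc(NS(=O)(=O)/C=C/c2c(F)c(F)c(F)c(F)c2F)cc1[N+](=O)[O-]`: 100000 nM
compound 2, `COc1ccc(NS(=O)(=O)/C=C/c2c(F)c(F)c(F)c(F)c2F)cc1N`: 75000 nM
compound 3, `COc1ccc(NS(=O)(=O)/C=C/c2c(OC)cc(OCCCC(=O)O)cc2OC)cc1[N+](=O)[O-]`: 100000 nM

All three were read in a functional assay on DU-145 cells (Homo sapiens) for cytotoxicity, read by trypan blue exclusion, with a stated time of 96 h; a higher number here means a weaker inhibitor, a lower number a stronger inhibitor. Compound 1 gives 100000 nM there, compound 2 gives 75000 nM, and compound 3 gives 100000 nM, level with compound 1 at the digits shown, the two together the highest numbers of the set. The step of a 1.3-fold lower number from compound 1 to compound 2 (0.12 log units; within the scatter) follows the change (amino in place of nitro on an aromatic carbon). Compound 4, `COc1ccc(NS(=O)(=O)/C=C/c2c(OC)cc(OCCCC(=O)O)cc2OC)cc1N`, carries the same change on the core of compound 3: amino in place of nitro on an aromatic carbon. The surroundings of the change read the same in both pairs, so this counts as the same change; the difference between the two cores is not broken down here. Since compound 1 and compound 3 stand level in this assay, the expectation is that the change behaves on the second core as on the first, which rests on the step of a 1.3-fold lower number from compound 1 to compound 2 (0.12 log units; within the scatter). The step expected on that basis is a 1.3-fold lower number from compound 3 to compound 4 (0.10 log units; within the scatter), within the scatter. Compound 4 is therefore estimated at 80000 nM, with the expected range running from 30000 nM to 150000 nM.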

Compound 4, half-maximal inhibitory concentration: 10000 nM
Beside the measured number, compound 4's estimate is 8.0-fold (0.90 log units) above it, outside the stated range (below it).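

In this assay, amino in place of nitro on an aromatic carbon gives a 10-fold lower number from compound 3 to compound 4 (1.00 log units; beyond the scatter), so the size of the step does not carry over from the core of compound 1 to the core of compound 3: the same change on two cores in this assay, a 1.3-fold lower number (0.12 log units; within the scatter) from compound 1 to compound 2 and a 10-fold lower number (1.00 log units; beyond the scatter) from compound 3 to compound 4, 7.5-fold (0.88 log units) apart, beyond the scatter of two such steps. For these two pairs, then, the step read on one core is no reliable guide to the step on the other, even though compound 1 and compound 3 stand level before the change. Two pairs give no rule for any further core, and they do not show which difference between the two cores goes with the gap, or why the gap arises.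

The compounds shown leave open whether the larger step on the core of compound 3 would persist with a methyl ester in place of the carboxylic acid, or with a shorter chain carrying that acid. They also leave open how an acetamide in place of the amino group would read on either core.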